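The source may report more compounds than this note shows. Statements on the series, on what has been measured and on what is new or still open speak of the compounds shown alone.

Measured compounds in an assay on cells with melanin-concentrating hormone receptor 1 (Homo sapiens) as the target, read by radioligand binding; a lower number here means a stronger inhibitor, a higher number a weaker inhibitor:
- compound 1 `CC(CC(C)(C)C)Oc1cccc2cccnc12`: > 2000 nM
- compound 2 `CCOCCOc1cccc2ccc(N)nc12`: > 2000 nM
- compound 3 `Nc1ccc2cccc(OCC3CCCO3)c2n1`: > 2000 nM

Compound 1 stands only at a limit of this assay, > 2000 nM, not at a number. Compound 2 likewise returns a limit, > 2000 nM. Compound 3 returns a limit as well, > 2000 nM. For the measured compounds named here, the whole measured set therefore sits at one point, (the limit of > 2000 nM in this assay, at which 3 of the 3 values shown sit), and no compound can be ranked against another. Going by the values given here, the single step between measured neighbours, a step that the two limits leave unreadable from compound 2 to compound 3, is unreadable for that reason and gives no size.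

Compound 4 `CC(CC(C)(C)C)Oc1cccc2ccc(N3CCCC3)nc12` is the next member, differing from compound 1 by pyrrolidin-1-yl in place of hydrogen on an aromatic carbon. Among the compounds with values here, no measured step touches this change: compounds 2 and 3 carry an amino group on the shared core and both stop at the limit, while compound 1 carries only hydrogen there and also stops at the limit. Nothing measured here points in either direction, so the expectation stays close to the limit with a wide spread. Compound 4 is expected to give about 1500 nM, within 200 nM to 10000 nM. For compound 4 this means an expected step of an at least 1.3-fold lower number from compound 1 to compound 4 (0.12 log units; that floor lies within the scatter), with a substantial chance that only a limit is reported.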

Compound 4, half-maximal inhibitory concentration: > 2000 nM
Compound 4 ended at the assay's limit (the forecaster's own chance of this, stated with the estimate: 55%); middle value at least 1.3-fold (0.12 log units) away from the limit.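

In this assay, compound 1 and compound 4 both stand at a limit, so the step between them cannot be read: the limit of > 2000 nM in this assay, at which 4 of the 4 values shown sit.

The compounds shown leave open whether pyrrolidin-1-yl in place of hydrogen shifts the value at all, and what on the shared core would give a number in this assay.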